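Permeability notes: from compound 2 to compound 3

A few compounds are considered here, and "the series" means these few. Any claim that something is new, unique, unknown or untested is made for them only; others in the source may bear on it.

Measured in an ADME assay for permeability, using PAMPA, in phosphate buffer, with a stated time of 18 h, at pH 7.4; on this read-out higher numbers stand for higher permeability and lower numbers for lower permeability:
- compound 1 `Cc1ccc(N2CCN(c3nc4cc(N)ccc4o3)CC2)cc1` gives 10.4 10^-6 cm/s
- compound 2 `COc1ccc(N2CCN(c3nc4cc(N)ccc4o3)CC2)cc1` gives 10.5 10^-6 cm/s

Compound 1 stands level with compound 2 at 10.5 10^-6 cm/s, and the two cannot be told apart. Compound 3 `Nc1ccc2oc(N3CCN(c4ccccn4)CC3)nc2c1` carries pyridin-2-yl in place of 4-methoxyphenyl on an amine nitrogen in a ring. Within the data shown here, the only measured step is a 1.0-fold higher number from compound 1 to compound 2 (0.00 log units; within the scatter), with methoxy in place of methyl on an aromatic carbon. It bears only loosely on this change, since that aromatic ring stays in place there. No step beyond the scatter is expected in this assay, and the estimated step is a 1.3-fold lower number from compound 2 to compound 3 (0.12 log units; within the scatter). The estimate for compound 3 is 8 10^-6 cm/s, with an expected range from 3.5 10^-6 cm/s to 14 10^-6 cm/s.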

Compound 3, apparent permeability: 9.44 10^-6 cm/s
The estimate for compound 3 lay 1.2-fold (0.07 log units) below the measured number; measured number inside the range.
By their numbers in this assay, from the lowest: compounds 3, 1 and 2 (each within the scatter of the next).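

In this assay, replacing the aromatic ring itself on the amine nitrogen in a ring, which the earlier step left in place, gives a 1.1-fold lower number from compound 2 to compound 3 (0.05 log units; within the scatter) with pyridin-2-yl in place of 4-methoxyphenyl. Pyridin-2-yl in place of 4-methylphenyl gives a 1.1-fold lower number from compound 1 to compound 3 (0.04 log units; within the scatter). Across compound 1, compound 2 and compound 3, a six-membered aromatic ring with 1 hetero atom and one of carbon only therefore stand level at this position.

As far as these compounds go, whether a non-aromatic group such as cyclohexyl, or a phenyl ring carrying a carboxylic acid, would stay at this level remains open. No measured evidence bears on this result.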